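Trading the Methyl Ether for a Free Hydroxyl

A few compounds are considered here, and "the series" means these few. Any claim that something is new, unique, unknown or untested is made for them only; others in the source may bear on it.

Measured so far in a functional assay on RXF 393 cells (Homo sapiens) for cytotoxicity, read by sulforhodamine B assay, with a stated time of 48 h, tested at 1 uM; a lower number here means a stronger effect, a higher number a weaker effect of the compound at the concentration tested:
compound 1, `Cc1cc(O)cc(-c2nn(CC#N)cc2-c2ccnc(-c3ccc(Oc4ccccc4)cc3)c2)c1`, gives -58%;
compound 2, `COc1cc(C)cc(-c2nn(CC#N)cc2-c2ccnc(-c3ccc(N(C)C)cc3)c2)c1`, gives -21%.

Compound 2 holds the highest of the two numbers. Its nearest neighbour, compound 1, returns a number lower by a margin beyond the usual scatter. Going by the values given here, the two compounds differ in more than one place, so no single step joins them, and nothing is known about how either change contributes on its own.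

Compound 3, `Cc1cc(O)cc(-c2nn(CC#N)cc2-c2ccnc(-c3ccc(N(C)C)cc3)c2)c1`, has not yet been measured. It arises from compound 2 by one change, hydrogen in place of methyl on an oxygen on an aromatic ring: methoxy becomes hydroxy, so the 3-methoxy-5-methylphenyl of compound 2 becomes the 3-hydroxy-5-methylphenyl that compound 1 also carries. Among the compounds with values here, no measured pair isolates this change, so the expectation rests on compound 1, which carries the same 3-hydroxy-5-methylphenyl and gives -58% in this assay. For compound 3 the step of a number 19 percentage points lower from compound 2 to compound 3 (beyond the scatter) is expected, downward and beyond the scatter, though smaller than the whole gap to compound 1. Compound 3 is therefore estimated at -40%, within -65% to -15%.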

Compound 3, a percentage reported as activity, at one concentration (the size of the read-out at that concentration, not a potency): -32%
Estimate against measurement, compound 3: 8 percentage points below; the measured number falls inside the stated range.
By their numbers in this assay, from the lowest: compound 1; then compound 3; then compound 2.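

In this assay, the change from methoxy to hydroxy now stands on its own: with the dimethylamino group held fixed, hydrogen in place of methyl on the oxygen gives a number 11 percentage points lower from compound 2 to compound 3 (beyond the scatter), a modest step. Compound 3 also isolates the second place, since with the 3-hydroxy-5-methylphenyl held fixed, dimethylamino in place of phenoxy on an aromatic carbon gives a number 26 percentage points higher from compound 1 to compound 3 (beyond the scatter), so each of the two differences between compound 1 and compound 2 now has a step of its own, and both steps are beyond the scatter. Nothing measured here explains why either change moves the number in this way.

From the compounds shown here alone, whether hydrogen in place of methyl on that oxygen gives a similar step when phenoxy, rather than dimethylamino, is carried by the other ring remains open. Going by these compounds, it is also open how other groups would read in place of the hydroxy, such as an amine, a carboxylic acid or a longer chain like ethoxy, and how a group such as morpholine would read in place of dimethylamino.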